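From compound 2 to compound 4: a new group on nitrogen

The compounds below may be only part of what the source reports. "The series", "measured", "known", "first", "only" and "open" are said of these compounds alone.

In a functional assay on HCT-116 cells (Homo sapiens) for cytotoxicity, read by MTT assay, with a stated time of 72 h (a higher number here means a weaker inhibitor, a lower number a stronger inhibitor), compound 1 `COc1cc(Nc2nc3ccccc3nc2S(=O)(=O)c2ccccc2)cc(OC)c1` gives 950 nM. Compound 2 `COc1cc(Nc2nc3ccccc3nc2S(=O)(=O)c2ccc(C)cc2)cc(OC)c1` gives > 50000 nM, which is a limit of the assay and not a number. Compound 3 `COc1cc(Nc2nc3ccccc3nc2S(=O)(=O)c2ccc(C)cc2)cc(OC)c1OC` gives 10800 nM. Compound 4 `Cc1ccc(S(=O)(=O)c2nc3ccccc3nc2Nc2cccc(O)c2)cc1` is related to compound 2 by 3-hydroxyphenyl in place of 3,5-dimethoxyphenyl on a nitrogen on an aromatic ring.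

The large at least 52-fold higher number from compound 1 to compound 2 (1.72 log units; beyond the scatter) changes another part of the structure, so it bears only on the starting point. The at least modest an at least 4.6-fold lower number from compound 2 to compound 3 (0.66 log units; beyond the scatter) changes the group being replaced and is the closer precedent, though neither step tests 3-hydroxyphenyl. A step towards a lower number is therefore expected, with an at least 3.3-fold lower number from compound 2 to compound 4 (0.52 log units; beyond the scatter) as the estimate. Compound 4 is expected at 15000 nM, within an estimated range of 2500 nM to 50000 nM.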

Compound 4, half-maximal inhibitory concentration: 3810 nM
For compound 4 the middle estimate is 3.9-fold (0.60 log units) above the measured one, within the range that was stated.
By their numbers in this assay, from the lowest: compound 1; then compound 4; then compound 3. At a limit, above all of these: compound 2.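

In this assay, the step to 3-hydroxyphenyl on the nitrogen is an at least 13-fold lower number from compound 2 to compound 4 (1.11 log units; beyond the scatter). Compounds 1, 2 and 3 all carry methoxy groups on this ring, whereas compound 4 has none and still gives a measured value. Compound 2 stands at a limit and not a number, so the step has only one bound: the limit of > 50000 nM in this assay, at which 1 of the 4 values shown sits.

Going by these compounds, the change removes both methoxy groups and adds the hydroxyl at once, so the share of each stays open. Also open, on these data alone, is how an amine or a carboxylic acid in place of the hydroxyl would read.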